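The compounds below may be only part of what the source reports. "The series", "measured", "known", "first", "only" and "open" are said of these compounds alone.

Measured compounds:
compound 1, `Cc1cccc(N(C)C(=N)Nc2cccc3ccccc23)c1`: 1860 nM
compound 2, `CN(C(=N)Nc1cccc2ccccc12)c1cccc([N+](=O)[O-])c1`: 6260 nM
compound 3, `CN(C(=N)Nc1cccc2ccccc12)c1cccc(N)c1`: 2700 nM

Three compounds sharing one core, differing only in the group on an aromatic carbon, were tested in an assay on membranes from brain (Cavia porcellus) for binding affinity to Sigma non-opioid intracellular receptor 1 (Homo sapiens), read by radioligand binding; a lower number here means a stronger inhibitor, a higher number a weaker inhibitor. Compound 3 gives 2700 nM there, the second highest of the three numbers; its nearest neighbour is compound 1, with a step of a 1.5-fold higher number from compound 1 to compound 3 (0.16 log units; within the scatter), and its furthest is compound 2, with a step of a 2.3-fold lower number from compound 2 to compound 3 (0.37 log units; beyond the scatter). The step of a 3.4-fold higher number from compound 1 to compound 2 (0.53 log units; beyond the scatter) sets the widest span seen so far.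

Compound 4, `CN(C(=N)Nc1cccc2ccccc12)c1cccc(N=[N+]=[N-])c1`, has not yet been measured. Its change from compound 3 is azido in place of amino on an aromatic carbon. Within the data shown here, the steps that bear on it are the two that swap the group at this same place into or out of an amino group; the whole set spans only a modest range, and a change from amino to azido is of similar kind. The expected step is therefore a 1.2-fold lower number from compound 3 to compound 4 (0.09 log units; within the scatter), not beyond the scatter. Compound 4 is expected to give about 2200 nM in this assay, within a range from 900 nM to 5500 nM.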

Compound 4, half-maximal inhibitory concentration: 3020 nM
The estimate for compound 4 lay 1.4-fold (0.14 log units) below the measured number; measured number inside the range.
By their numbers in this assay, from the lowest: compounds 1, 3 and 4 (each within the scatter of the next); then compound 2.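

In this assay, azido in place of amino gives a 1.1-fold higher number from compound 3 to compound 4 (0.05 log units; within the scatter), so removing the hydrogen-bond donor of the amino group at this position shifts the number by no more than the scatter, and azido also stays within the scatter of methyl, at a 1.6-fold higher number from compound 1 to compound 4 (0.21 log units; within the scatter). Compound 2 now stands apart from all three other compounds, with a 2.1-fold lower number from compound 2 to compound 4 (0.32 log units; beyond the scatter), so among the four groups, nitro alone gives a number beyond the scatter of the others. Nothing given here explains why nitro differs from azido, amino and methyl.

The compounds shown leave open whether a carboxylic acid, a nitrile or a longer chain such as propyl at this place would stay with the azido, amino and methyl compounds or fall with nitro. They also leave open whether any group here could bring a number clearly below that of compound 1.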